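A few compounds are considered here, and "the series" means these few. Any claim that something is new, unique, unknown or untested is made for them only; others in the source may bear on it.

Three compounds of the series have numbers in a physicochemical assay for lipophilicity; on this read-out higher numbers stand for higher lipophilicity and lower numbers for lower lipophilicity. Compound 1 `CC(C)(C)n1ncc(OCc2nnc(-c3ccc(Cl)cc3Cl)o2)c(Cl)c1=O` gives 3.52 in this assay, compound 3 `CCc1ccc(-c2nnc(COc3cnn(C(C)(C)C)c(=O)c3Cl)o2)cc1` gives 3.52, and compound 2 `CC(C)(C)n1ncc(OCc2nnc(-c3ccccc3F)o2)c(Cl)c1=O` gives 2.89. Compound 2 stands lowest of the three: a number 0.63 log units lower from compound 1 to compound 2 (beyond the scatter), and a number 0.63 log units higher from compound 2 to compound 3 (beyond the scatter). Between the other two, no change at the digits printed from compound 1 to compound 3 (within the scatter).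

Compound 4 `CC(C)(C)n1ncc(OCc2nnc(-c3c(F)cccc3F)o2)c(Cl)c1=O` has not been measured in this assay. It differs from compound 2 by fluoro in place of hydrogen on an aromatic carbon. Within the data shown here, no measured step contains this change. The two steps that touch compound 2 each exchange the whole aryl group and both were modest in size; a single fluoro in place of hydrogen is a smaller change than either of those exchanges, and nothing in the measured numbers points to a large step. A small rise in this assay is expected, one that stays within the scatter, so that the step from compound 2 to compound 4 is estimated as a number 0.16 log units higher from compound 2 to compound 4 (within the scatter). Compound 4 is therefore expected at 3.05, with a range from 2.75 to 3.35.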

Compound 4, partition coefficient: 2.75
The estimate for compound 4 lay 0.30 log units above the measured number, and the stated range covers the measured number.
By their numbers in this assay, from the lowest: compounds 4 and 2 (each within the scatter of the next); then compounds 1 and 3 (each within the scatter of the next).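

In this assay, among these compounds, fluoro in place of hydrogen on an aromatic carbon, ortho to a large group, is the first change of a single atom, and it gives a number 0.14 log units lower from compound 2 to compound 4 (within the scatter); at this position, 2-fluorophenyl and 2,6-difluorophenyl cannot be told apart on this read-out. Against the two other aryl groups, 2,6-difluorophenyl stays beyond the scatter, with a number 0.77 log units lower from compound 3 to compound 4 (beyond the scatter) and a number 0.77 log units lower from compound 1 to compound 4 (beyond the scatter). Nothing at hand bears on the reason for these numbers.

As far as these compounds go, the fluoro change rests on one pair of compounds, so its size on another aryl group remains open. Also open, from the compounds shown here alone, is how this assay responds when an amine, a carboxylic acid or a methoxy group stands on this ring in place of fluoro.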